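The compounds below may be only part of what the source reports. "The series", "measured", "known", "first", "only" and "open" are said of these compounds alone.

Values in an ADME assay on MT4 cells (Homo sapiens) for cytotoxicity, read by MTT assay, with a stated time of 3 days; a higher number here means that more compound is tolerated, a lower number that less compound is tolerated:

compound 1 `CC(C)(C)N(Cc1ccc([N+](=O)[O-])cc1)C(=O)COC(=O)c1ccc([N+](=O)[O-])o1` gives > 100000 nM, a limit
compound 2 `COc1ccc(CN(C(=O)COC(=O)c2ccc([N+](=O)[O-])o2)C(C)(C)C)cc1` gives > 100000 nM, a limit
compound 3 `CC(C)(C)N(Cc1ccc(OCc2ccccc2)cc1)C(=O)COC(=O)c1ccc([N+](=O)[O-])o1` gives "not active" (no number reported)

Compound 3 carries no number at all, only the report "not active" (no number reported). The readings for compound 1 and compound 2 are limits and not numbers, so what the series offers is the limit of > 100000 nM in this assay, at which 2 of the 3 values shown sit.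

Compound 4 `CC(C)(C)N(Cc1ccc(F)cc1)C(=O)COC(=O)c1ccc([N+](=O)[O-])o1` changes compound 3 at one place: fluoro in place of benzyloxy on an aromatic carbon. Fluoro takes the place of benzyloxy on an aromatic carbon.

Within the data shown here, only one measured change falls at this aromatic carbon, methoxy in place of nitro, and it is a step that the two limits leave unreadable from compound 1 to compound 2. Resting on that step, no definite size can be carried over to the new change. No step beyond the usual scatter is therefore expected in this assay, in either direction, and compound 4 is expected to stay close to the same limit.

The estimate for compound 4 is 90000 nM, with an expected range from 35000 nM to 100000 nM.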

Compound 4, half-maximal cytotoxic concentration: > 100000 nM
Compound 4 ended at the assay's limit; the forecaster's own chance of this, stated with the estimate: 70%; middle value at least 1.1-fold (0.04 log units) away from the limit.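

In this assay compound 4 gives > 100000 nM, a limit. Compound 1 and compound 2 also stand at limits, so no step among these three compounds can be read. The compounds shown leave open at what concentration any of them becomes cytotoxic, and whether fluoro, methoxy and nitro differ at all.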